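A few compounds are considered here, and "the series" means these few. Any claim that something is new, unique, unknown or untested is made for them only; others in the source may bear on it.

Compound 1: `COc1cc(/C=C/C(=O)c2ccc(OCC=C(C)C)cc2O)cc(OC)c1OC`, > 100000 nM
Compound 2: `COc1ccc(/C=C/C(=O)c2ccc(OCC=C(C)C)cc2OCC=C(C)C)c(OC)c1OC`, 49000 nM
Compound 3: `COc1ccc(/C=C/C(=O)c2ccc(OCC=C(C)C)cc2OCC=C(C)C)cc1OC`, 9000 nM
Compound 4: `COc1cc(/C=C/C(=O)c2ccc(OCC=C(C)C)cc2OCC=C(C)C)cc(OC)c1OC`, not yet measured

For the measured compounds named here, in an assay on isolated protein for inhibition of Polyunsaturated fatty acid 5-lipoxygenase (Homo sapiens) (a higher number here means a weaker inhibitor, a lower number a stronger inhibitor), compound 3 gives 9000 nM, the lowest of the two numbers measured so far. Compound 2 gives 49000 nM in this assay. For compound 1 this assay reports only a limit and not a number, namely (the limit of > 100000 nM in this assay, at which 1 of the 3 values shown sits).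

Going by the values given here, the single measured step, a 5.4-fold lower number from compound 2 to compound 3 (0.74 log units; beyond the scatter), took a methoxy group away. The change that leads to compound 4 goes the other way: methoxy in place of hydrogen on an aromatic carbon. Adding a methoxy group is the reverse kind of change, so a move toward a higher number, of about the same modest size, is expected. Compound 1 carries the same three methoxy groups as compound 4 while differing elsewhere, and it sits at a limit; that points the same way but supplies no number.

Compound 4 is therefore expected to give 35000 nM, between 9000 nM and 100000 nM. This amounts to an expected step of a 3.9-fold higher number from compound 3 to compound 4 (0.59 log units; beyond the scatter).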

Compound 4, half-maximal inhibitory concentration: 4000 nM
Beside the measured number, compound 4's estimate is 8.8-fold (0.94 log units) above it; measured number outside the range, below it.
By their numbers in this assay, from the lowest: compound 4; then compound 3; then compound 2. At a limit, above all of these: compound 1.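

Placed on this aromatic carbon, ortho to a methoxy group, a new methoxy does not raise the number: the change gives a 2.3-fold lower number from compound 3 to compound 4 (0.35 log units; beyond the scatter). In the earlier step, losing a methoxy elsewhere on the ring also lowered the number, so a methoxy's effect on this ring depends on where it sits rather than simply on its presence. The other change, 3-methylbut-2-en-1-yl in place of hydrogen on an oxygen on an aromatic ring, gives an at least 25-fold lower number from compound 1 to compound 4 (1.39 log units; beyond the scatter), a large step against the modest methoxy change, and compound 1 stands at a limit, not a number: the limit of > 100000 nM in this assay, at which 1 of the 4 values shown sits.

As far as these compounds go, it remains open whether a hydroxyl, a fluorine or an amine on this carbon would do as well as methoxy. From the compounds shown here alone, it is equally open whether a shorter or longer chain could replace the 3-methylbut-2-en-1-yl groups.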